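The compounds below may be only part of what the source reports. "The series", "measured", "known", "first", "only" and "open" are said of these compounds alone.

Compound 1 `O=[N+]([O-])c1ccc(CN2CCC(n3cc(CC(OCc4cc(-c5ccccc5)no4)c4ccc(Br)cc4)nn3)CC2)cc1` gives 7000 nM in a functional assay on Caco-2 cells (Homo sapiens) for cytotoxicity, with a stated time of 48 h (on this read-out lower numbers stand for stronger inhibition and higher numbers for weaker inhibition), the higher of the two numbers recorded, while compound 2 `O=[N+]([O-])c1ccc(CN2CCC(n3cc(CC(OCc4cc(-c5ccc(F)cc5)no4)c4ccc(Br)cc4)nn3)CC2)cc1` gives 3000 nM in this assay. Among the measured compounds shown here, the single measured step, a 2.3-fold lower number from compound 1 to compound 2 (0.37 log units; beyond the scatter), lies beyond the scatter. Compound 3 `O=[N+]([O-])c1ccc(CN2CCC(n3cc(CC(OCc4cc(-c5cccc(Br)c5)no4)c4ccc(Br)cc4)nn3)CC2)cc1` differs from compound 1 by bromo in place of hydrogen on an aromatic carbon, so that phenyl becomes 3-bromophenyl. Only a 2.3-fold lower number from compound 1 to compound 2 (0.37 log units; beyond the scatter) bears on this, a change of the same kind, and its size points to a modest lowering. Compound 3 is therefore expected to give about 4000 nM, within 1500 nM to 10000 nM, an estimated step of a 1.8-fold lower number from compound 1 to compound 3 (0.24 log units; within the scatter).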

Compound 3, half-maximal inhibitory concentration: 5000 nM
Beside the measured number, compound 3's estimate is 1.3-fold (0.10 log units) below it, and the stated range covers the measured number.
By their numbers in this assay, from the lowest: compounds 2, 3 and 1 (each within the scatter of the next, the first and the last beyond it).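

Bromo on an aromatic carbon meta to a large group, turning phenyl into 3-bromophenyl, gives a 1.4-fold lower number from compound 1 to compound 3 (0.15 log units; within the scatter) in this assay and so does not separate the two compounds on this read-out. Exchanging 4-fluorophenyl for 3-bromophenyl gives a 1.7-fold higher number from compound 2 to compound 3 (0.22 log units; within the scatter) and likewise leaves those two compounds unseparated. Nothing available explains these numbers.

On these data alone, whether an amine or a carboxylic acid at this ring carbon would give a step beyond the scatter remains open. So does the effect of bromo on another carbon of this ring.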